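A few compounds are considered here, and "the series" means these few. Any claim that something is new, unique, unknown or untested is made for them only; others in the source may bear on it.

In a functional assay on the whole organism (strain Wistar) with Rattus norvegicus as the target, with a stated time of 15 days, at a dose of 10 mg/kg by the oral route (on this read-out higher numbers stand for a stronger effect at the one dose given and lower numbers for a weaker effect), two compounds have been measured so far. Compound 1 `O=C1NC(=O)/C(=C/c2ccc(OCCSc3nnc(Cc4ccccc4)[nH]3)cc2)S1` gives 22.8%. Compound 2 `Cc1ccc(-c2nnc(SCCOc3ccc(/C=C4\SC(=O)NC4=O)cc3)[nH]2)cc1` gives 21.7%. Compound 2 stands together with compound 1; the two numbers lie within the usual scatter of each other, so neither can be called the stronger. Among the measured compounds shown here, the one measured step, a number 1.1 percentage points lower from compound 1 to compound 2 (within the scatter), is the only guide to what exchanging the group at this place does, and it moved the read-out no further than repeated measurements would. Compound 3 `O=C1NC(=O)/C(=C/c2ccc(OCCSc3nnc(-c4ccccc4[N+](=O)[O-])[nH]3)cc2)S1` differs from compound 2 by 2-nitrophenyl in place of 4-methylphenyl on an aromatic carbon. Nothing measured shows how 2-nitrophenyl at this place behaves, so the earlier exchange is the only lead. The expected step is therefore a number 0.3 percentage points higher from compound 2 to compound 3 (within the scatter), a change no larger than the scatter. For compound 3 the estimated value in this assay is 22%, with a range from 8% to 38%.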

Compound 3, a percentage reported as activity, at one dose (the size of the read-out at that dose, not a potency): 20.9%
For compound 3 the middle estimate is 1.1 percentage points above the measured one; low and high end bracket the measured number.
By their numbers in this assay, from the lowest: compounds 3, 2 and 1 (each within the scatter of the next).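

In this assay, 2-nitrophenyl in place of 4-methylphenyl on the aromatic carbon gives a number 0.8 percentage points lower from compound 2 to compound 3 (within the scatter), and 2-nitrophenyl in place of benzyl gives a number 1.9 percentage points lower from compound 1 to compound 3 (within the scatter). The position has now carried a third group, and the first with hydrogen-bond acceptors, 2 of them, yet all three compounds remain within the scatter of one another, so no group among them can be ranked over another. Nothing available bears on why these exchanges leave the read-out unresolved.

From the compounds shown here alone, all three groups carry a six-membered aromatic ring of carbon only, so it remains open whether a group without such a ring, such as an amine or a carboxylic acid, would separate from them. A longer chain between this ring and the core is also untested here, as is any dose other than the single one given.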